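A few compounds are considered here, and "the series" means these few. Any claim that something is new, unique, unknown or untested is made for them only; others in the source may bear on it.

Measured compounds:
compound 1 `OCCC(NC1CCN(CCCc2c[nH]c3ccc(-n4cnnc4)cc23)CC1)c1ccccc1`, 5.5 nM;
compound 2 `CC#CCN(C)C1CCN(CCCc2c[nH]c3ccc(-n4cnnc4)cc23)CC1`, 9.8 nM;
compound 3 `CC(=O)Nc1ccc([C@@H](C)NC2CCN(CCCc3c[nH]c4ccc(-n5cnnc5)cc34)CC2)cc1`, 29 nM.

In an assay on CHO cells for binding affinity to 5-hydroxytryptamine receptor 1D (Homo sapiens) (on this read-out higher numbers stand for weaker inhibition and lower numbers for stronger inhibition), compound 3 stands highest of the three numbers: compound 2 sits a 1.8-fold higher number from compound 1 to compound 2 (0.25 log units; within the scatter) from compound 1, a step within the scatter, whereas compound 3 sits a 5.3-fold higher number from compound 1 to compound 3 (0.72 log units; beyond the scatter) from compound 1, a modest step beyond the scatter. Compound 4 `CC(CO)(NC1CCN(CCCc2c[nH]c3ccc(-n4cnnc4)cc23)CC1)c1ccccc1` changes compound 3 at the amine nitrogen: 1-(hydroxymethyl)-1-phenylethyl in place of 1-(4-acetamidophenyl)ethyl on an amine nitrogen.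

Among the measured compounds shown here, the step that bears most on this change is the one from compound 1 to compound 3, since the group entering in compound 4 carries a phenyl ring and a hydroxy group much as the group of compound 1 does, and that step was a 5.3-fold higher number from compound 1 to compound 3 (0.72 log units; beyond the scatter). The step from compound 1 to compound 2 shows that a different substituent on the same amine nitrogen left the number within the scatter. On this basis the number for compound 4 is expected to fall back toward that of compound 1, an expected 2.9-fold lower number from compound 3 to compound 4 (0.46 log units; beyond the scatter) in this assay. Compound 4 is therefore estimated at 10 nM, with a range of 3.5 nM to 30 nM.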

Compound 4, half-maximal inhibitory concentration: 5.2 nM
For compound 4 the middle estimate is 1.9-fold (0.28 log units) above the measured one; low and high end bracket the measured number.
By their numbers in this assay, from the lowest: compounds 4, 1 and 2 (each within the scatter of the next); then compound 3.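

In this assay, 1-(hydroxymethyl)-1-phenylethyl in place of 1-(4-acetamidophenyl)ethyl on the amine nitrogen gave a 5.6-fold lower number from compound 3 to compound 4 (0.75 log units; beyond the scatter), a modest step beyond the scatter. The new group sits level with 3-hydroxy-1-phenylpropyl, at a 1.1-fold lower number from compound 1 to compound 4 (0.02 log units; within the scatter), and with (but-2-yn-1-yl)(methyl)amino on the saturated ring carbon, at a 1.9-fold lower number from compound 2 to compound 4 (0.28 log units; within the scatter), both within the scatter, so that among these four compounds only compound 3 stands apart. No measurement given here accounts for this.

It remains open whether the acetamido group itself sets compound 3 apart, since a plain 1-phenylethyl group on the amine nitrogen is not among the compounds shown. Also open, on these data alone, is how this position would respond if a primary amine or a carboxylic acid took the place of the hydroxy group in the hydroxymethyl arm of compound 4.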